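The source may report more compounds than this note shows. Statements on the series, on what has been measured and on what is new or still open speak of the compounds shown alone.

Compound 1 `O=S(=O)(/C=C/c1ccccn1)c1ccccc1F` is a vinyl sulfone in which a pyridin-2-yl group sits on the double-bonded chain. In an assay on U2OS cells for activation of nuclear factor erythroid 2-related factor 2 (Homo sapiens), read by beta-arrestin recruitment, with a stated time of 6 h (a lower number here means that less compound is needed, a higher number that more compound is needed for the effect), compound 1 gives 1050 nM. Compound 2 `O=S(=O)(/C=C/c1ncccc1Cl)c1ccccc1F` differs from compound 1 by chloro in place of hydrogen on an aromatic carbon; the step is a 35-fold lower number from compound 1 to compound 2 (1.54 log units; beyond the scatter), so compound 2 gives 30 nM in this assay. Compound 3 `O=S(=O)(/C=C/c1cccnc1)c1ccccc1F` shares the atoms of compound 1 but joins them differently, the change being (pyridin-3-yl in place of pyridin-2-yl on a double-bonded chain carbon bound to a double-bonded chain carbon); the step is a 6.5-fold higher number from compound 1 to compound 3 (0.82 log units; beyond the scatter), and compound 3 gives 6860 nM in this assay, the highest number of the three measured compounds.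

Compound 4 `O=S(=O)(/C=C/c1cccnc1Cl)c1ccccc1F` has not yet been measured. It differs from compound 3 by chloro in place of hydrogen on an aromatic carbon. This is the same kind of change as that from compound 1 to compound 2, but not the same: in compound 2 the chloro is two atoms from the ring nitrogen, whereas in compound 4 it is next to the ring nitrogen, and the core is that of compound 3 rather than compound 1. Among the measured compounds shown here, because of a 35-fold lower number from compound 1 to compound 2 (1.54 log units; beyond the scatter), a clear drop in number is expected from compound 3 to compound 4, though a smaller one, since only a single example of this step exists and it sits on a different core and position. The expected step is a 9.8-fold lower number from compound 3 to compound 4 (0.99 log units; beyond the scatter). Compound 4 is therefore estimated to give 700 nM in this assay, with a range from 150 nM to 3000 nM.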

Compound 4, half-maximal effective concentration: 217 nM
Compound 4: middle estimate off by 3.2-fold (0.51 log units), on the high side; measured number inside the range.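

Putting chloro in place of hydrogen on the core of compound 3, on an aromatic carbon next to the ring nitrogen, gives a 32-fold lower number from compound 3 to compound 4 (1.50 log units; beyond the scatter) in this assay. Among the compounds shown here, the change therefore lowers the number by about the same amount on both cores, and the two steps cannot be told apart: the same change on two cores in this assay, a 35-fold lower number (1.54 log units; beyond the scatter) from compound 1 to compound 2 and a 32-fold lower number (1.50 log units; beyond the scatter) from compound 3 to compound 4, 1.1-fold (0.04 log units) apart, within the scatter of two such steps This rests on only two pairs of compounds in a single assay, so it shows that the step carried over here but gives no general rule for other cores, and it does not explain why the number falls.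

Among the compounds shown, chloro is the only group that replaces this hydrogen, so it remains open whether fluoro, bromo, methyl or methoxy would lower the number to a similar extent. As far as these compounds go, it is also open whether the chloro step would keep its size on a core in which an amine or a carboxylic acid takes the place of the fluoro group.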